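The source may hold more compounds than are shown below. What is called first, only, known or untested is meant among the compounds shown, and "the series" means these compounds.

Measured compounds:
Compound 1, `Cc1nc(S(C)(=O)=O)ccc1Oc1ncnc(OC2CCN(C(=O)OC(C)C)CC2)c1F` — in a functional assay on isolated protein for inhibition of Glucose-dependent insulinotropic receptor (Rattus norvegicus), read by HTRF and cAMP accumulation (on this read-out lower numbers stand for smaller maximal responses and higher numbers for larger maximal responses), compound 1 gives 77%
Compound 2, `Cc1nc(S(C)(=O)=O)ccc1Oc1ncnc(OC2CCN(C(=O)OC3COC3)CC2)c1F` — compound 2 gives 66%
Compound 3, `CCc1cnc(C(=O)N2CCC(Oc3ncnc(Oc4ccc(S(C)(=O)=O)nc4C)c3F)CC2)nc1` — compound 3 gives 80%

Compound 3 has the highest of the three numbers, but its gap to compound 1 is within the usual scatter, so the two cannot be ranked against each other; only compound 2 sits clearly lower, as the step of a number 14 percentage points higher from compound 2 to compound 3 (beyond the scatter) shows. The other measured steps, a number 11 percentage points lower from compound 1 to compound 2 (beyond the scatter) and a number 3 percentage points higher from compound 1 to compound 3 (within the scatter), all concern the group carried on the carbonyl carbon of the shared core.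

Compound 4, `Cc1nc(S(C)(=O)=O)ccc1Oc1ncnc(OC2CCN(C(=O)c3ncc(Cl)cn3)CC2)c1F`, keeps the carbonyl group of compound 3 and changes the ring attached to it: chloro in place of ethyl on an aromatic carbon. Going by the values given here, no measured step touches this ring, so the measured steps give no direct guidance here; they only show that maximal responses have stayed within a narrow band. A step within the scatter is therefore expected, a number 2 percentage points lower from compound 3 to compound 4 (within the scatter). Compound 4 is estimated at 78%, with a range from 66% to 90%.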

Compound 4, largest response reached (reported as efficacy), in percent of the reference or control that the assay uses: 77%
Beside the measured number, compound 4's estimate is 1 percentage points above it; low and high end bracket the measured number.
By their numbers in this assay, from the lowest: compound 2; then compounds 1, 4 and 3 (each within the scatter of the next).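

Swapping ethyl for chloro on this aromatic ring gives a number 3 percentage points lower from compound 3 to compound 4 (within the scatter) in this assay and so shows no measurable shift in maximal response for this change at this position. Replacing isopropoxy on the carbonyl carbon with 5-chloropyrimidin-2-yl gives no change at the digits printed from compound 1 to compound 4 (within the scatter) as well, whereas replacing (oxetan-3-yl)oxy with the same group gives a number 11 percentage points higher from compound 2 to compound 4 (beyond the scatter) and leaves compound 2 as the only one of the four that sits clearly lower. Nothing available here explains why the numbers fall as they do.

What remains open is how far this position stays insensitive, since only ethyl and chloro are shown on it. An amine, a methoxy group or a longer chain such as butyl in the same place could keep the maximal response in this band or move it clearly away.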